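Swapping 2-chloroethyl for 2-chloroethoxy on a carbonyl carbon

A few compounds are considered here, and "the series" means these few. Any claim that something is new, unique, unknown or untested is made for them only; others in the source may bear on it.

Values in a functional assay on the whole organism for inhibition, with Mus musculus as the target; on this read-out lower numbers stand for an effect already at smaller amounts and higher numbers for an effect only at larger amounts of compound:
- compound 1 `CN1Cc2c(NC(=O)CCl)cccc2C(c2ccccc2)C1`: 3 mg/kg
- compound 2 `CN1Cc2c(NC(=O)CCCl)cccc2C(c2ccccc2)C1`: 8.8 mg/kg

Of these two, compound 2 has the higher number, 8.8 mg/kg, so its effect appears only at a larger dose. Compound 3 `CN1Cc2c(NC(=O)OCCCl)cccc2C(c2ccccc2)C1` keeps the shared core and carries 2-chloroethoxy in place of 2-chloroethyl on a carbonyl carbon. For the measured compounds named here, only one measured step bears on this, a 2.9-fold higher number from compound 1 to compound 2 (0.47 log units; beyond the scatter), a modest change on a saturated chain carbon bound to a carbonyl carbon. It is a different swap, so it offers only a rough size and no direction. In this assay, no clear step beyond the scatter is expected, although a modest one in either direction is possible. The expected change is a 1.5-fold lower number from compound 2 to compound 3 (0.17 log units; within the scatter). For compound 3 the estimated value is 6 mg/kg, with an expected range of 2 mg/kg to 20 mg/kg.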

Compound 3, dose for half-maximal effect: 2.5 mg/kg
Beside the measured number, compound 3's estimate is 2.4-fold (0.38 log units) above it, and the stated range covers the measured number.
By their numbers in this assay, from the lowest: compounds 3 and 1 (each within the scatter of the next); then compound 2.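

In this assay the swap of 2-chloroethyl for 2-chloroethoxy on this carbonyl carbon gives a 3.5-fold lower number from compound 2 to compound 3 (0.55 log units; beyond the scatter) and so shows that this position responds to the change in the chain. Set against the chloromethyl compound, the same group gives a 1.2-fold lower number from compound 1 to compound 3 (0.08 log units; within the scatter) and so brings back the low dose that the 2-chloroethyl chain had lost. No measurement here explains this shift.

The compounds shown leave open whether the chlorine is needed, which a plain ethoxy group on the same carbonyl carbon would test. A longer chloroalkoxy chain would show how far this chain can grow.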